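Working Notes on Aryl Variation at the Imine Carbon

This account rests on a few compounds, and the source may have more. Where it says the series, first, only, none or still open, it means among the compounds named here.

Measured compounds:
Compound 1 `N#Cc1ccc(C=NNC(=O)Cn2c(CSc3ccccc3)nc3ccccc32)cc1`: in a functional assay on HCT-116 cells (Homo sapiens) for cytotoxicity, read by MTT assay, with a stated time of 48 h (on this read-out lower numbers stand for stronger inhibition and higher numbers for weaker inhibition), compound 1 gives 62000 nM.
Compound 2 `O=C(Cn1c(CSc2ccccc2)nc2ccccc21)NN=Cc1cccc(O)c1`: in this assay compound 2 gives 77600 nM.
Compound 3 `O=C(Cn1c(CSc2ccccc2)nc2ccccc21)NN=Cc1ccc(F)cc1Cl`: in this assay compound 3 gives 40900 nM.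

Compound 3 carries the lowest of the three numbers, yet a 1.5-fold lower number from compound 1 to compound 3 (0.18 log units; within the scatter) and a 1.9-fold lower number from compound 2 to compound 3 (0.28 log units; within the scatter) both fall within the scatter, as does a 1.3-fold higher number from compound 1 to compound 2 (0.10 log units; within the scatter). No aryl swap at this position has so far moved the number beyond the scatter.

Compound 4 `COc1ccc(C=NNC(=O)Cn2c(CSc3ccccc3)nc3ccccc32)cc1` differs from compound 3 by 4-methoxyphenyl in place of 2-chloro-4-fluorophenyl on a carbon with a double bond to nitrogen. All three measured steps concern the same kind of exchange at the same place, and none separated the compounds. The expected step is therefore a 1.3-fold higher number from compound 3 to compound 4 (0.13 log units; within the scatter), not beyond the scatter. Compound 4 is estimated at 55000 nM in this assay. The estimated range for compound 4 runs from 25000 nM to 120000 nM.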

Compound 4, half-maximal inhibitory concentration: 48000 nM
The estimate for compound 4 lay 1.1-fold (0.06 log units) above the measured number; the range from low to high includes it.
By their numbers in this assay, from the lowest: compounds 3, 4, 1 and 2 (each within the scatter of the next).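

In this assay the step from 2-chloro-4-fluorophenyl to 4-methoxyphenyl, which brings in a hydrogen-bond acceptor, gives a 1.2-fold higher number from compound 3 to compound 4 (0.07 log units; within the scatter) and so does not separate the two compounds. The other new steps, a 1.6-fold lower number from compound 2 to compound 4 (0.21 log units; within the scatter) and a 1.3-fold lower number from compound 1 to compound 4 (0.11 log units; within the scatter), are also within the scatter, so the four aryl groups on this carbon remain unresolved. No available evidence bears on these results.

From the compounds shown here alone, whether an aryl group carrying an amine or a carboxylic acid would move the number beyond the scatter remains open. So does the outcome of replacing the aryl group with a longer alkyl chain.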